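The source may report more compounds than this note shows. Statements on the series, on what has been measured and on what is new or still open speak of the compounds shown alone.

In a functional assay on WHCO1 cells (Homo sapiens) for cytotoxicity, read by MTT assay, with a stated time of 24 h (a higher number here means a weaker inhibitor, a lower number a stronger inhibitor), compound 1 `C=CC(O)C1=CC(=O)c2ccccc2C1=O` gives 4300 nM, and compound 2 `O=C1C=C([C@@H](O)c2ccccc2)C(=O)c2ccccc21` gives 3800 nM. Compound 2 carries the lower of the two numbers, yet its gap to compound 1 sits within the scatter, so no order between them can be read. Compound 3 `O=C1C=C([C@H](O)c2ccccc2)C(=O)c2ccccc21` is the next step: the two compounds have the same atoms and bonds and differ only in configuration as drawn: 1 of 1 stereo elements differ; a stereocentre at a saturated chain carbon is drawn S in compound 2 and R in compound 3. Within the data shown here, no measured pair in this set shows what such an inversion does here. On that basis the expected step is a 1.1-fold higher number from compound 2 to compound 3 (0.02 log units; within the scatter), nothing beyond the scatter in either direction. For compound 3 in this assay the expected value is 4000 nM, with a range from 1500 nM to 10000 nM.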

Compound 3, half-maximal inhibitory concentration: 4300 nM
Compound 3: the middle estimate sits 1.1-fold (0.03 log units) below what was measured; low and high end bracket the measured number.
By their numbers in this assay, from the lowest: compounds 2, 1 and 3 (each within the scatter of the next).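

In this assay, among these compounds, inverting the stereocentre at the saturated chain carbon gives a 1.1-fold higher number from compound 2 to compound 3 (0.05 log units; within the scatter), the first direct reading of configuration at this position. No preference for S or R can be read from this pair. The reading concerns configuration alone, on this ground: the fact that compounds 2 and 3 differ only in the configuration as drawn.

Going by these compounds, whether an amine in place of the hydroxyl on this carbon, or a longer chain in place of the phenyl, would move the number beyond the scatter remains open. Also open, on these data alone, is whether the inversion would stay this small with such a group in place.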